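From 2-methoxyphenyl to 4-methylphenyl on a shared core

The source may report more compounds than this note shows. Statements on the series, on what has been measured and on what is new or still open speak of the compounds shown alone.

Measured so far in a functional assay on PANC-1 cells (Homo sapiens) for inhibition, read by MTT assay, with a stated time of 24 h; a higher number here means a weaker inhibitor, a lower number a stronger inhibitor:
- compound 1 `CC1(C)[C@H]2CC[C@]1(C)N(Cc1cn(-c3cccc(C#N)c3)nn1)C(=O)C2` gives 260 nM
- compound 2 `CC1(C)[C@H]2CC[C@]1(C)N(Cc1cn(-c3cccc(Cl)c3)nn1)C(=O)C2` gives 260 nM
- compound 3 `COc1ccccc1-n1cc(CN2C(=O)C[C@@H]3CC[C@@]2(C)C3(C)C)nn1` gives 120 nM

Compound 3, at 120 nM, has the lowest number of the three, which makes it the strongest inhibitor measured in this assay. The other two cannot be told apart, as the step between them shows: no change at the digits printed from compound 1 to compound 2 (within the scatter).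

Compound 4 `Cc1ccc(-n2cc(CN3C(=O)C[C@@H]4CC[C@@]3(C)C4(C)C)nn2)cc1` has not yet been measured. It keeps the shared core but carries 4-methylphenyl in place of 2-methoxyphenyl on an aromatic nitrogen of a five-membered aromatic ring with 3 nitrogen (4-methylphenyl in place of 2-methoxyphenyl on an aromatic nitrogen).

Among the measured compounds shown here, no measured compound carries 4-methylphenyl, so the evidence is indirect. Two measured steps compare other groups at this place with 2-methoxyphenyl: a 2.2-fold lower number from compound 1 to compound 3 (0.34 log units; beyond the scatter), and a 2.2-fold lower number from compound 2 to compound 3 (0.34 log units; beyond the scatter). Both are modest, and both favour the compound holding 2-methoxyphenyl. Compound 4 loses that group, so a modest rise in the number is expected, though it may stay within the scatter. The expected change is a 1.9-fold higher number from compound 3 to compound 4 (0.28 log units; within the scatter). For compound 4 the estimated value is 230 nM, with an expected range of 110 nM to 480 nM.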

Compound 4, half-maximal inhibitory concentration: 270 nM
The estimate for compound 4 lay 1.2-fold (0.07 log units) below the measured number; low and high end bracket the measured number.
By their numbers in this assay, from the lowest: compound 3; then compounds 1, 2 and 4 (each within the scatter of the next).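

Among the groups on this ring nitrogen, the move away from 2-methoxyphenyl now has a third reading in this assay: replacing it with 4-methylphenyl gives a 2.3-fold higher number from compound 3 to compound 4 (0.35 log units; beyond the scatter), a modest step in the same direction as the two earlier ones. The new group cannot be told apart from the other two, with a 1.0-fold higher number from compound 2 to compound 4 (0.02 log units; within the scatter) and a 1.0-fold higher number from compound 1 to compound 4 (0.02 log units; within the scatter), so 3-cyanophenyl, 3-chlorophenyl and 4-methylphenyl form one group of equal numbers, and among these four compounds only compound 3, the strongest inhibitor of the set, stands apart from them. Nothing among the data shown explains why 2-methoxyphenyl gives the lower number.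

Going by these compounds, whether that lower number belongs to the methoxy group itself or to where it sits on the phenyl ring remains open. Also open, on these data alone, is how a longer ether such as ethoxy, or an amine or a carboxylic acid on the same phenyl ring, would behave in this assay on this shared core.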